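The source may report more compounds than this note shows. Statements on the series, on what has been measured and on what is new or still open speak of the compounds shown alone.

Working notes on the series. Compound 1 `CO/N=C(\C)CN1CCN(c2c(F)cc3c(=O)c(C(=O)O)cn(C4CC4)c3c2OC)CC1C` is measured in an ADME assay on Vero cells (Chlorocebus sabaeus) for cytotoxicity, read by MTT assay, with a stated time of 72 h (a higher number here means that more compound is tolerated, a lower number that less compound is tolerated), where compound 1 gives 49.6 ug/mL. Compound 2 `CCO/N=C(\C)CN1CCN(c2c(F)cc3c(=O)c(C(=O)O)cn(C4CC4)c3c2OC)CC1C` carries methyl in place of hydrogen on a saturated chain carbon bound to an oxygen on an unsaturated carbon relative to compound 1, and in this assay compound 2 gives 31.3 ug/mL; the step is a 1.6-fold lower number from compound 1 to compound 2 (0.20 log units; within the scatter). Compound 3 `CO/N=C(\C)CCN1CCN(c2c(F)cc3c(=O)c(C(=O)O)cn(C4CC4)c3c2OC)CC1C` differs from compound 1 in the core, the difference being (a group of 6 heavy atoms (4 carbon, 1 nitrogen, 1 oxygen; no ring) in place of a group of 5 heavy atoms (3 carbon, 1 nitrogen, 1 oxygen; no ring), on a saturated chain carbon bound to an amine nitrogen in a ring). In this assay compound 3 gives 157 ug/mL, with a 3.2-fold higher number from compound 1 to compound 3 (0.50 log units; beyond the scatter) and a 5.0-fold higher number from compound 2 to compound 3 (0.70 log units; beyond the scatter), so compound 3 stands highest of the three measured numbers.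

Compound 4 `CCO/N=C(\C)CCN1CCN(c2c(F)cc3c(=O)c(C(=O)O)cn(C4CC4)c3c2OC)CC1C` is not yet measured. From compound 3 it carries methyl in place of hydrogen on a saturated chain carbon bound to an oxygen on an unsaturated carbon, the same change as from compound 1 to compound 2, where the step was a 1.6-fold lower number from compound 1 to compound 2 (0.20 log units; within the scatter). Compound 4 is expected to show a step of a 1.6-fold lower number from compound 3 to compound 4 (0.20 log units; within the scatter) in this assay, within the scatter, because the earlier step of a 1.6-fold lower number from compound 1 to compound 2 (0.20 log units; within the scatter) was of that size and no other instance of the change exists among these compounds. Compound 4 is therefore estimated at 100 ug/mL, with a range from 50 ug/mL to 200 ug/mL.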

Compound 4, half-maximal cytotoxic concentration: 88.4 ug/mL
Compound 4: middle estimate off by 1.1-fold (0.05 log units), on the high side; low and high end bracket the measured number.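

In this assay the change from methoxy to ethoxy reads alike on both cores, with a 1.8-fold lower number from compound 3 to compound 4 (0.25 log units; within the scatter) set beside the earlier pair as follows: the same change on two cores in this assay, a 1.6-fold lower number (0.20 log units; within the scatter) from compound 1 to compound 2 and a 1.8-fold lower number (0.25 log units; within the scatter) from compound 3 to compound 4, 1.1-fold (0.05 log units) apart, within the scatter of two such steps. Both steps lie within the scatter, so the two pairs show that the change carries between these two cores without a gap that can be told from the scatter, but they show no effect of the change itself and say nothing about any other core. With ethoxy held, a 2.8-fold higher number from compound 2 to compound 4 (0.45 log units; beyond the scatter) is a step on the saturated chain carbon bound to an amine nitrogen in a ring, whereas a 1.8-fold higher number from compound 1 to compound 4 (0.25 log units; within the scatter) combines that difference with the methyl and cannot separate the two.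

On these data alone, whether the same holds for a longer chain on the oxygen, such as propoxy, or a branched one, such as isopropoxy, stays open. So does the reading for an amine or a carboxylic acid at the end of that chain.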